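The compounds below may be only part of what the source reports. "The series", "measured", "known", "first", "only" and "open" are said of these compounds alone.

Notes on the series, following the step from compound 1 `CC1(C)c2[nH]nc(NC(=O)c3ccc(F)cc3)c2CN1C(=O)C1CCN(C2CC2)CC1` to compound 4 `CC(C)(C)C(=O)N1Cc2c(NC(=O)c3ccc(F)cc3)n[nH]c2C1(C)C`. In a physicochemical assay for solubility, at pH 7 (on this read-out higher numbers stand for higher solubility and lower numbers for lower solubility), compound 1 gives > 225000 nM, which is a limit of the assay and not a number. Compound 2 `CC(C)CC(=O)Nc1n[nH]c2c1CN(C(=O)C1CCN(C3CC3)CC1)C2(C)C` likewise sits at a limit in this assay, at > 225000 nM. Compound 3 `CN1CCC(C(=O)N2Cc3c(NC(=O)c4ccc(F)c(F)c4)n[nH]c3C2(C)C)CC1` also sits at a limit in this assay, at > 225000 nM. Within the data shown here, the only step within the measured set, a step that the two limits leave unreadable from compound 1 to compound 2, is unreadable for that reason, and all three values share (the limit of > 225000 nM in this assay, at which 3 of the 3 values shown sit). Compound 1 therefore stands only at a limit, with no number to place it against the others. The change to compound 4 is tert-butyl in place of 1-cyclopropylpiperidin-4-yl on a carbonyl carbon. Among the measured compounds shown here, no measured step touches the group that leaves: compound 2 and compound 3 both keep a ring-bearing group on that carbonyl carbon. Direction and size of the step in this assay thus cannot be read from the series, and the estimate below carries a wide range. Compound 4 is expected to give 50000 nM, between 8000 nM and 225000 nM. The expected step of an at least 4.5-fold lower number from compound 1 to compound 4 (0.65 log units; beyond the scatter) thus points downward, with a real chance that only a limit is reported again.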

Compound 4, solubility: 235000 nM
The estimate for compound 4 lay 4.7-fold (0.67 log units) below the measured number; the measured number lies above the stated range.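

No new step can be read between compound 1 and compound 4 in this assay. Compound 1 gives > 225000 nM, which is a limit and not a number. Going by these compounds, whether tert-butyl in place of 1-cyclopropylpiperidin-4-yl on a carbonyl carbon raises or lowers the read-out remains open.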